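The compounds below may be only part of what the source reports. "The series", "measured", "known", "first", "only" and "open" are said of these compounds alone.

In a functional assay on a cell-free system (Platelet, plasma, Homo sapiens) for inhibition, read by turbidimetry, with a stated time of 3 min (on this read-out higher numbers stand for weaker inhibition and lower numbers for stronger inhibition), the measured compounds give:
compound 1 (`COc1ccc(-n2nc(C(=O)N3CCOCC3)cc2-c2ccc(Cl)cc2)nn1`): 83 nM
compound 2 (`COc1ccc(-n2nc(C(=O)Nc3ccncc3)cc2-c2ccc(Cl)cc2)nn1`): 110 nM
compound 3 (`COc1ccc(-n2nc(C(=O)N3CCN(c4ccc(C)cc4)CC3)cc2-c2ccc(Cl)cc2)nn1`): 4670 nM

Compound 3 has the highest number of the three, and both others lie below it beyond the scatter. Compound 4 (`COc1ccc(-n2nc(C(=O)N3CCN(c4ccc(C(F)(F)F)cn4)CC3)cc2-c2ccc(Cl)cc2)nn1`) carries 5-(trifluoromethyl)pyridin-2-yl in place of 4-methylphenyl on an amine nitrogen in a ring. For the measured compounds named here, the one measured step (a 1.3-fold higher number from compound 1 to compound 2 (0.12 log units; within the scatter)) is a different change, (pyridin-4-yl)amino in place of morpholin-4-yl on a carbonyl carbon, and no measured step alters the group exchanged here. No step beyond the scatter is therefore expected in this assay in either direction, and the expected step (a 1.3-fold lower number from compound 3 to compound 4 (0.13 log units; within the scatter)) is small. For compound 4 the estimated value is 3500 nM with an expected range from 900 nM to 12000 nM on this thin evidence.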

Compound 4, half-maximal inhibitory concentration: 5490 nM
Estimate against measurement, compound 4: 1.6-fold (0.20 log units) below, and the stated range covers the measured number.
By their numbers in this assay, from the lowest: compounds 1 and 2 (each within the scatter of the next); then compounds 3 and 4 (each within the scatter of the next).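

In this assay, 5-(trifluoromethyl)pyridin-2-yl in place of 4-methylphenyl on this amine nitrogen gives a 1.2-fold higher number from compound 3 to compound 4 (0.07 log units; within the scatter) and so leaves the read-out unmoved, even though the entering group adds heavy atoms, a ring nitrogen and a hydrogen-bond acceptor. At this position, then, the two rings are not told apart, and compound 4 stays with compound 3 at the high end of the series. Nothing available bears on why they read alike.

From the compounds shown here alone, whether a methyl or acetyl group on the same nitrogen would read differently from these two rings remains open.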